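Swapping an Amide for Thiophene on a Serotonin Receptor Probe

A few compounds are considered here, and "the series" means these few. Any claim that something is new, unique, unknown or untested is made for them only; others in the source may bear on it.

Two compounds have been examined for their ability to displace a radioactive tracer from a serotonin receptor subtype, measured as an assay on HEK293 cells for binding affinity to 5-hydroxytryptamine receptor 7 (Homo sapiens), read by radioligand binding, tested at 1 uM; a higher number here means more inhibition at the concentration tested (going by the name of the read-out), a lower number less inhibition. Compound 1 `Brc1cccc2ccn(CCN3CCN4CCCCC4C3)c12` gives 13% in this assay, while compound 2 `CN1CCCN(CCn2ccc3ccc(C(N)=O)cc32)CC1` gives 33%. Compound 2 therefore shows the higher of the two numbers, and its lead over compound 1 is wide enough to lie outside the usual scatter of repeated measurements.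

Compound 3 `CN1CCCN(CCn2ccc3ccc(-c4ccsc4)cc32)CC1` has not been measured yet. It differs from compound 2 in one place only: thiophen-3-yl in place of carbamoyl on an aromatic carbon. The carbamoyl that leaves carries a hydrogen-bond donor; the thiophen-3-yl that enters carries none and adds an aromatic ring instead.

Among the compounds with values here, no measured pair in this set shows what such a replacement does, so the size and direction of the step cannot be read from the data. The expectation is a step from compound 2 to compound 3 of about a number 2 percentage points higher from compound 2 to compound 3 (within the scatter), that is, no clear change beyond the scatter in either direction. On that basis compound 3 is estimated to give 35% in this assay, within a broad range from 10% to 65%.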

Compound 3, a percentage reported as inhibition, at one concentration (the size of the read-out at that concentration, not a potency): 68%
The estimate for compound 3 lay 33 percentage points below the measured number; the whole stated range lies below it.
By their numbers in this assay, from the lowest: compound 1; then compound 2; then compound 3.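

At this aromatic carbon, the group attached clearly matters: in this assay, thiophen-3-yl in place of carbamoyl gives a number 35 percentage points higher from compound 2 to compound 3 (beyond the scatter), and this large step comes from a change in one place on an otherwise shared structure. The amide's hydrogen-bond donor is therefore not required for a sizeable reading, since compound 3 has no donor in the group at this position. However, the change removes that donor and adds an aromatic ring in a single move, so this pair cannot show which of the two differences accounts for the step, and nothing available explains its cause.

The compounds shown leave open whether thiophene itself matters or whether another aromatic ring, such as phenyl or furan-3-yl, would give a similar reading, and whether moving the attachment to thiophen-2-yl would change it. They also leave open how a plain hydrogen on this carbon would compare, which would help separate the loss of carbamoyl from the gain of thiophen-3-yl, and a reading at one concentration is not a measure of potency.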